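A new group on the carbonyl carbon of compound 3

This account rests on a few compounds, and the source may have more. Where it says the series, first, only, none or still open, it means among the compounds named here.

Three measured compounds share one core and differ in the group on a carbonyl carbon. In an in vitro ADME assay on microsomes from liver (Rattus norvegicus) for metabolic stability, tested at 1 uM (a lower number here means that the compound disappears faster, a higher number that the compound lasts longer), compound 1 `O=C(c1cccnc1)N1CCC(NS(=O)(=O)c2cc(S(=O)(=O)c3ccccc3)ccc2C(F)(F)F)CC1` gives 0.0333 h, while compound 2 `O=C(c1ccc(Cl)nc1)N1CCC(NS(=O)(=O)c2cc(S(=O)(=O)c3ccccc3)ccc2C(F)(F)F)CC1` gives 0.15 h. Chloro in place of hydrogen on an aromatic carbon thus brings a 4.5-fold higher number from compound 1 to compound 2 (0.65 log units; beyond the scatter).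

Compound 3 `O=C(CC1CCNCC1)N1CCC(NS(=O)(=O)c2cc(S(=O)(=O)c3ccccc3)ccc2C(F)(F)F)CC1` gives > 0.5 h, which is a limit of the assay and not a number.

Putting (piperidin-4-yl)methyl in place of pyridin-3-yl gives an at least 15-fold higher number from compound 1 to compound 3 (1.17 log units; beyond the scatter). Putting it in place of 6-chloropyridin-3-yl gives an at least 3.3-fold higher number from compound 2 to compound 3 (0.52 log units; beyond the scatter). Both steps remove an aromatic group and bring in a six-membered non-aromatic ring.

Compound 4 `O=C([C@@H]1CCNC1)N1CCC(NS(=O)(=O)c2cc(S(=O)(=O)c3ccccc3)ccc2C(F)(F)F)CC1` has pyrrolidin-3-yl in place of (piperidin-4-yl)methyl on a carbonyl carbon. The new group keeps a non-aromatic ring with one hetero atom, though that ring is five-membered. Within the data shown here, no measured step exchanges one such group for another, so the evidence is indirect. The large gain of an at least 15-fold higher number from compound 1 to compound 3 (1.17 log units; beyond the scatter) came with leaving the aromatic group, and compound 4 has none there either. The expected change is a number no higher from compound 3 to compound 4 (the limit leaves the size open), a step not expected to go beyond the scatter in this assay. For compound 4 the estimated half-life is 0.5 h, with an expected range from 0.2 h to 1 h.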

Compound 4, half-life: > 0.5 h
Compound 4: no number, only a limit; the forecaster's own chance of this, stated with the estimate: 55%; the middle value sits exactly at the limit.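

On the carbonyl carbon, pyrrolidin-3-yl gives an at least 15-fold higher number from compound 1 to compound 4 (1.17 log units; beyond the scatter) and an at least 3.3-fold higher number from compound 2 to compound 4 (0.52 log units; beyond the scatter) in this assay. The large gain over compound 1 is therefore no longer seen with (piperidin-4-yl)methyl alone: among the four compounds shown, both groups with a non-aromatic ring outlast both groups with a pyridine ring, even though the five-membered ring of compound 4 belongs to a smaller group. The step from compound 3 to compound 4 cannot be read, because neither compound has a number and each stops at the same assay limit: the limit of > 0.5 h in this assay, at which 2 of the 4 values shown sit.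

On these data alone, how far compound 3 and compound 4 lie past that limit remains open, and so does whether ring size or the defined stereocentre of compound 4 changes the half-life at all. Also open, as far as these compounds go, is whether the ring nitrogen matters, which a group such as cyclopentyl, with carbon in place of that nitrogen, could test at this position.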